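This account rests on a few compounds, and the source may have more. Where it says the series, first, only, none or still open, it means among the compounds named here.

Measured so far:
Compound 1 `c1ccc(-c2ccc(Cn3cncc3CNc3cccc(-c4ccccc4)c3)cc2)cc1`: 10000 nM.
Compound 2 `COC(=O)c1ccc(NCc2cncn2Cc2ccccc2C)cc1-c1ccccc1`: 10000 nM.
Compound 3 `COC(=O)c1ccc(NCc2cncn2Cc2cccc(F)c2)cc1-c1ccccc1`: > 1000 nM.

All three values come from a toxicity assay on NIH3T3 cells (Mus musculus) for cytotoxicity, read by resazurin assay; on this read-out higher numbers stand for an effect only at larger amounts of compound and lower numbers for an effect already at smaller amounts. In this test compound 1 gives 10000 nM, and compound 2 stands level with it at 10000 nM. Compound 3 is reported as > 1000 nM, which is a limit of the assay and not a number.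

The next compound to consider is compound 4 `CCOC(=O)c1ccc(NCc2cncn2Cc2ccc(-c3ccccc3)cc2)cc1-c1ccccc1`. It differs from compound 1 by ethoxycarbonyl in place of hydrogen on an aromatic carbon. In words, ethoxycarbonyl takes the place of hydrogen on an aromatic carbon, ortho to a phenyl group and para to a large group.

Going by the values given here, no measured step isolates this change. Among the compounds with values here, the only step available, a step that the limit leaves unreadable from compound 2 to compound 3, concerns a different place in the molecule and gives no size to carry over. The nearest guide is therefore the pair of values themselves: despite their different structures, compound 1 and compound 2 show the same number in this assay. Nothing measured points to a shift in either direction, so the expected result is no change at the digits printed from compound 1 to compound 4 (within the scatter), with no change beyond the scatter. For compound 4 the estimated value is 10000 nM, with an expected range from 3000 nM to 20000 nM.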

Compound 4, half-maximal effective concentration: > 10000 nM
Compound 4: no number, only a limit; the forecaster's own chance of this, stated with the estimate: 35%; the middle value lies on the limit itself.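

Compound 4 is reported in this assay as > 10000 nM, which is a limit of the assay and not a number. Placing ethoxycarbonyl on this aromatic carbon, ortho to a phenyl group and para to a large group, gives a number no lower from compound 1 to compound 4 (the limit leaves the size open), so a group of 5 heavy atoms with no ring and no net charge can enter here without the effect moving to smaller amounts of compound. This is the only step shown that concerns this aromatic carbon, and neither its size nor that of the step between compound 2 and compound 3 can be read: the limit of > 10000 nM in this assay, at which 1 of the 4 values shown sits.

The compounds shown leave open whether a carboxylic acid or an amine on this same aromatic carbon would also keep the effect from moving to smaller amounts of compound. They also leave open whether a longer chain in place of the ethyl part of the ester would give a readable number in this assay.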